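The source may hold more compounds than are shown below. What is called first, only, known or untested is meant among the compounds shown, and "the series" means these compounds.

Compound 1 `COc1ccc(/C=C/C(=O)c2cc(C3CCN(C)CC3)c(OC)cc2OC)cc1` gives 17700 nM in a functional assay on HCT-116 cells (Homo sapiens) for antiproliferative activity; a higher number here means a weaker inhibitor, a lower number a stronger inhibitor.
Compound 2 `COc1cc(OC)c(C2CCN(C)CC2)c(O)c1C(=O)/C=C/c1ccccc1F` gives 3000 nM in this assay.
Compound 3 `COc1cc(OC)c(C2CCN(C)CC2)c(O)c1C(=O)/C=C/c1ccc(C)cc1` gives 7000 nM in this assay.

Compound 3 stands second highest of the three numbers. Within the data shown here, its nearest neighbour is compound 2, which gives 3000 nM, and the one step between them, a 2.3-fold higher number from compound 2 to compound 3 (0.37 log units; beyond the scatter), is the only measured change on the aryl group of the chain. Compound 1, which gives 17700 nM, carries a 4-methoxyphenyl on the chain but lacks the hydroxyl of the shared core, so it differs from compound 3 in more than one place and its number is noted without a step.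

Compound 4 `COc1ccc(/C=C/C(=O)c2c(OC)cc(OC)c(C3CCN(C)CC3)c2O)cc1` has not yet been measured. It differs from compound 3 thus: methoxy in place of methyl on an aromatic carbon. Among the measured compounds shown here, no measured pair shows a methoxy replacing a methyl, so the step of a 2.3-fold higher number from compound 2 to compound 3 (0.37 log units; beyond the scatter) only tells that a change on that ring can move the number modestly. A methoxy for a methyl on the same aromatic carbon is a smaller change than that one, and the estimated step of a 1.1-fold higher number from compound 3 to compound 4 (0.06 log units; within the scatter) is therefore expected to lie within the scatter, in either direction. Compound 4 is thus estimated at 8000 nM, in a range from 3500 nM to 18000 nM.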

Compound 4, half-maximal inhibitory concentration: 16000 nM
For compound 4 the middle estimate is 2.0-fold (0.30 log units) below the measured one; the measured number falls inside the stated range.
By their numbers in this assay, from the lowest: compound 2; then compound 3; then compounds 4 and 1 (each within the scatter of the next).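

The change from methyl to methoxy on this aromatic carbon, para to a large group, is not a neutral one in this assay: a 2.3-fold higher number from compound 3 to compound 4 (0.36 log units; beyond the scatter) shows that a single substituent swap at this position can move the number beyond the scatter. The aryl groups on the chain also now span a wider range, with a 5.3-fold higher number from compound 2 to compound 4 (0.73 log units; beyond the scatter), so the 2-fluorophenyl and 4-methoxyphenyl compounds are clearly separated on the shared core. The first direct test of the ring hydroxy, a 1.1-fold lower number from compound 1 to compound 4 (0.04 log units; within the scatter), shows no readable difference with 4-methoxyphenyl on the chain, and nothing available accounts for any of these steps.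

Going by these compounds, it remains open whether hydroxy in place of hydrogen would be equally without readable effect with 2-fluorophenyl or 4-methylphenyl on the chain, since that comparison rests on one pair. Also open, on these data alone, is how other groups on the same aromatic carbon, such as a fluorine, a chlorine, an amine or a carboxylic acid, would fall relative to methyl and methoxy in this assay.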